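Piperidinyl Substitution on the Core of Compound 1

The source may report more compounds than this note shows. Statements on the series, on what has been measured and on what is new or still open speak of the compounds shown alone.

Measured compounds:
- Compound 1, `CC(=O)NC(c1ccco1)c1cc(Cl)c2cccnc2c1O`: 3000 nM
- Compound 2, `CC(=O)NC(c1ccco1)c1cc(F)c2cccnc2c1O`: 5000 nM
- Compound 3, `CC(=O)NCc1cc(Cl)c2cccnc2c1O`: > 150000 nM

In an assay for inhibition of Polyunsaturated fatty acid lipoxygenase ALOX12 (Homo sapiens), read by spectrophotometry (on this read-out higher numbers stand for weaker inhibition and lower numbers for stronger inhibition), compound 1 gives 3000 nM, the lowest of the two numbers shown; compound 2 sits closest, and the step of a 1.7-fold higher number from compound 1 to compound 2 (0.22 log units; within the scatter) stays within the scatter. Compound 3 reaches only a limit of the assay, (the limit of > 150000 nM in this assay, at which 1 of the 3 values shown sits), and the step of an at least 50-fold higher number from compound 1 to compound 3 (1.69 log units; beyond the scatter) is large.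

Compound 4, `CC(=O)NC(c1ccco1)c1cc(Cl)c2ccc(N3CCCCC3)nc2c1O`, has not yet been measured. It differs from compound 1 by piperidin-1-yl in place of hydrogen on an aromatic carbon. Within the data shown here, neither measured step bears directly on this change: the halogen swap from compound 1 to compound 2 and the loss of the furan ring from compound 1 to compound 3 both touch other places on the shared core, and no measured compound carries a substituent on the aromatic carbon beside the ring nitrogen. The expected step of no change at the digits printed from compound 1 to compound 4 (within the scatter) is therefore one of no change beyond the scatter, with wide uncertainty. Compound 4 is expected to give about 3000 nM in this assay, estimated to lie between 800 nM and 12000 nM.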

Compound 4, half-maximal inhibitory concentration: > 75000 nM
Compound 4: a limit, no number; the forecaster's own chance of this, stated with the estimate: 10%; at least 25-fold (1.39 log units) between middle value and limit.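

The earlier compounds shown here changed only the halogen or the furan-2-yl group, and none of them showed what a substituent does on the aromatic carbon next to the ring nitrogen. Piperidin-1-yl in place of hydrogen at this carbon gives an at least 25-fold higher number from compound 1 to compound 4 (1.39 log units; beyond the scatter) in this assay and so shows that this position is not indifferent to substitution, as no earlier compound could. Compound 4 stands at a limit of the assay and gives no number: the limit of > 75000 nM in this assay, at which 1 of the 4 values shown sits.

The limit leaves the full size of this step unknown, and a single substituent cannot show whether the loss belongs to piperidin-1-yl in particular or to any group on this carbon. A methyl group, a dimethylamino group or a morpholin-4-yl ring at the same place would tell these cases apart, and the compounds shown also leave open whether the step would be the same with fluoro in place of chloro on the shared core.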